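The compounds below may be only part of what the source reports. "The series", "measured", "known", "first", "only" and "open" are said of these compounds alone.

compound 1 `S=C(NCc1ccccc1)N/N=C/c1ccc2ccccc2n1` — 21900 nM
compound 2 `NC(=S)N/N=C/c1cnc2ccccc2n1` — > 100000 nM
compound 3 `CC(C)c1cccc(C(C)C)c1NC(=S)N/N=C/c1ccc2ccccc2n1` — 19500 nM

All three thiosemicarbazones were examined in a functional assay on HL-60 cells (Homo sapiens) for antiproliferative activity, read by sulforhodamine B assay, with a stated time of 72 h; a lower number here means a stronger inhibitor, a higher number a weaker inhibitor. Compound 1 gives 21900 nM and compound 3 gives 19500 nM; these two numbers lie within the usual scatter of one another, so neither compound can be called the stronger of the pair. For compound 2 the assay reports only a limit and no number, (the limit of > 100000 nM in this assay, at which 1 of the 3 values shown sits). Compound 4 `S=C(N/N=C/c1ccc2ccccc2n1)Nc1ccccc1` has not yet been measured. It differs from compound 1 in a single place: phenyl in place of benzyl on an amide-type nitrogen. Within the data shown here, no pair of measured compounds shows the effect of this particular change, so no measured step can be brought to bear on it directly. The step is expected to be small, a 1.2-fold lower number from compound 1 to compound 4 (0.06 log units; within the scatter), and to stay within the scatter rather than move the number in either direction. Compound 4 is therefore expected to give about 19000 nM, most likely between 7000 nM and 55000 nM.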

Compound 4, half-maximal inhibitory concentration: 9130 nM
Estimate against measurement, compound 4: 2.1-fold (0.32 log units) above; the range from low to high includes it.
By their numbers in this assay, from the lowest: compound 4; then compounds 3 and 1 (each within the scatter of the next). At a limit, above all of these: compound 2.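

Phenyl in place of benzyl on an amide-type nitrogen gives, in this assay, a 2.4-fold lower number from compound 1 to compound 4 (0.38 log units; beyond the scatter). This is the only step shown at this position, and it establishes that the group on this nitrogen can move the number beyond the scatter. The two groups carry the same kind of aromatic ring and neither has a hydrogen-bond donor or acceptor, and nothing measured here accounts for the step.

The compounds shown leave open whether a 2-phenylethyl group on this nitrogen would continue the trend seen with benzyl and phenyl, and whether an amine or a carboxylic acid on the phenyl ring would move the number further. This single pair also cannot tell whether the step would hold on the core of compound 2.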